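Compound 3 gains a 4-fluorophenyl group

The source may hold more compounds than are shown below. What is called first, only, known or untested is meant among the compounds shown, and "the series" means these compounds.

In an ADME assay (liver) for metabolic stability, with Liver microsome (Homo sapiens) as the target, using microsomes (a lower number here means that the compound disappears faster, a higher number that the compound lasts longer), compound 1 `CCc1nc2cc(Cl)ccn2c1C(=O)NCc1ccc(-c2ccc(C)cc2)cc1` gives 0.423 h and compound 3 `CCc1nc2cc(Cl)ccn2c1C(=O)NCc1ccc(N2CCCCC2)cc1` gives 0.22 h as its half-life, the two lying within the scatter (a 1.9-fold lower number from compound 1 to compound 3 (0.28 log units; within the scatter)). Compound 2 `CCc1nc2cc(Cl)ccn2c1C(=O)NCc1ccc(-c2ccc(C(=O)O)cc2)cc1` reads > 2 h and this is a limit of the assay. Compound 3 stands well apart from that limit (an at least 9.0-fold lower number from compound 2 to compound 3 (0.95 log units; beyond the scatter)). Compound 4 `CCc1nc2cc(Cl)ccn2c1C(=O)NCc1ccc(N2CCC(c3ccc(F)cc3)CC2)cc1` has 4-fluorophenyl in place of hydrogen on a saturated ring carbon. Among the measured compounds shown here, no measured step touches that ring carbon. For the measured compounds named here, the only step beyond the scatter among compounds with a number or limit on this side came with carboxy (an at least 4.7-fold higher number from compound 1 to compound 2 (0.67 log units; beyond the scatter)) and compound 4 has none. No step beyond the scatter is therefore expected (a 1.1-fold higher number from compound 3 to compound 4 (0.06 log units; within the scatter)). For compound 4 the estimated half-life is 0.25 h within an expected range of 0.1 h to 0.6 h in this assay.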

Compound 4, half-life: 0.113 h
The estimate for compound 4 lay 2.2-fold (0.34 log units) above the measured number; the measured number falls inside the stated range.
By their numbers in this assay, from the lowest: compounds 4, 3 and 1 (each within the scatter of the next, the first and the last beyond it). At a limit, above all of these: compound 2.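

In this assay, among the compounds shown here, the first change at this saturated ring carbon, three ring bonds from the ring nitrogen, gives a 1.9-fold lower number from compound 3 to compound 4 (0.29 log units; within the scatter) and so no step beyond the scatter. A large aromatic group is thus accommodated here without a measurable change in half-life, and it does not produce the kind of step seen with carboxy in an at least 4.7-fold higher number from compound 1 to compound 2 (0.67 log units; beyond the scatter) on the other side of the molecule. The data shown offer no explanation for this reading. As far as these compounds go, whether a hydroxyl or an amine on this ring carbon would move the half-life beyond the scatter remains open.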